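The source may hold more compounds than are shown below. What is called first, only, known or untested is meant among the compounds shown, and "the series" means these compounds.

Compound 2, whose structure is `CCS(=O)(=O)Nc1cccc2c1CCCC2c1c[nH]cn1`, gives 1320 nM in an assay on isolated protein (Cricetulus griseus) for binding affinity to Alpha-1B adrenergic receptor (Mesocricetus auratus), read by radioligand binding; on this read-out higher numbers stand for weaker inhibition and lower numbers for stronger inhibition. Within the data shown here, that is the highest of the two numbers measured: its nearest neighbour, compound 1, `Oc1cccc2c1CCCC2c1c[nH]cn1`, gives 145 nM in this assay, and the one measured step, a 9.1-fold higher number from compound 1 to compound 2 (0.96 log units; beyond the scatter), is modest but beyond the scatter. Compound 3, `CC(=O)Nc1cccc2c1CCCC2c1c[nH]cn1`, has not yet been measured. It differs from compound 2 in one place: acetyl in place of ethylsulfonyl on a nitrogen on an aromatic ring.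

Among the measured compounds shown here, no measured step covers this exchange directly. The only step shown concerns the exchange of hydroxy for (ethylsulfonyl)amino, which raised the number in this assay from compound 1 to compound 2. The acetamido group of compound 3 is, by the counts given, smaller than the (ethylsulfonyl)amino of compound 2 but larger than the hydroxy of compound 1, so a number between those of compound 1 and compound 2 seems the most reasonable expectation, though the evidence is thin. For compound 3 a step of a 2.2-fold lower number from compound 2 to compound 3 (0.34 log units; beyond the scatter) is therefore expected, and the estimated value for compound 3 in this assay is 600 nM, with a plausible range from 200 nM to 2000 nM.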

Compound 3, inhibition constant: < 10000 nM
Compound 3 ended at the assay's limit; the forecaster's own chance of this, stated with the estimate: 3%; the middle value lies beyond the limit too.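

The steps from compound 1 to compound 3 and from compound 2 to compound 3 cannot be read. The compounds shown leave open how acetamido compares with hydroxy or with (ethylsulfonyl)amino on the shared core. In this assay compound 3 gives < 10000 nM and this is a limit, not a number: the limit of < 10000 nM in this assay, at which 1 of the 3 values shown sits.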